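A few compounds are considered here, and "the series" means these few. Any claim that something is new, unique, unknown or untested is made for them only; others in the source may bear on it.

In a functional assay on MCF7 cells (Homo sapiens) for antiproliferative activity, read by MTT assay, with a stated time of 72 h (a higher number here means a weaker inhibitor, a lower number a stronger inhibitor), three compounds built on a shared core have been measured. Compound 1 `COc1cc(/C=C/c2ccc(C3=C(c4ccc(O)cc4)C4CC(S(=O)(=O)Oc5ccccc5)C3O4)cc2)cc(OC)c1` reports only a limit, > 100000 nM. Among the compounds with values here, compound 2 `CCc1ccccc1OS(=O)(=O)C1CC2OC1C(c1ccc(/C=C/c3cc(OC)cc(OC)c3)cc1)=C2c1ccc(O)cc1` gives 49800 nM, while compound 3 `O=S(=O)(Oc1ccccc1)C1CC2OC1C(c1ccc(/C=C/c3cc(O)cc(O)c3)cc1)=C2c1ccc(O)cc1` gives 20100 nM, the lowest number measured so far. Compound 4 `O=S(=O)(Oc1ccccc1C(F)(F)F)C1CC2OC1C(c1ccc(/C=C/c3cc(O)cc(O)c3)cc1)=C2c1ccc(O)cc1` differs from compound 3 in one place: trifluoromethyl in place of hydrogen on an aromatic carbon. This is trifluoromethyl in place of hydrogen on an aromatic carbon, ortho to a large group, turning phenoxy into 2-(trifluoromethyl)phenoxy.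

Within the data shown here, the nearest precedent is the ethyl replacement on the same ring, an at least 2.0-fold lower number from compound 1 to compound 2 (0.30 log units; that floor lies within the scatter). That step is only a floor, and the floor lies within the scatter, so it hints at a lower number without establishing one. The other measured step, an at least 4.9-fold lower number from compound 1 to compound 3 (0.69 log units; beyond the scatter), lies beyond the scatter, but it changes a different place and says little about this ring. Among the measured compounds shown here, no measured pair shows a group added to this ring with the 3,5-dihydroxyphenyl present, and ethyl and trifluoromethyl are different groups. A small move toward a lower number in this assay is therefore expected, probably not clearly beyond the scatter. The expected move is a 1.3-fold lower number from compound 3 to compound 4 (0.13 log units; within the scatter). For compound 4 the estimated value is 15000 nM, with an expected range of 5000 nM to 45000 nM.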

Compound 4, half-maximal inhibitory concentration: 18300 nM
Compound 4: the middle estimate sits 1.2-fold (0.09 log units) below what was measured, and the stated range covers the measured number.
By their numbers in this assay, from the lowest: compounds 4 and 3 (each within the scatter of the next); then compound 2. At a limit, above all of these: compound 1.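

In this assay, trifluoromethyl on the phenoxy ring gives a 1.1-fold lower number from compound 3 to compound 4 (0.04 log units; within the scatter), so turning phenoxy into 2-(trifluoromethyl)phenoxy leaves no readable change in the number when the 3,5-dihydroxyphenyl is present. Within the data shown here, this is the first pair changed on this ring in which both ends are measured numbers, and the first with the 3,5-dihydroxyphenyl on both sides. The earlier ethyl step could give only a floor, because compound 1 stands at a limit: the limit of > 100000 nM in this assay, at which 1 of the 4 values shown sits.

Ethyl and trifluoromethyl on this ring are seen only with different groups at the far end of the double bond, so the compounds shown do not tell whether trifluoromethyl would give a similar result with the 3,5-dimethoxyphenyl, or ethyl with the 3,5-dihydroxyphenyl. Among these compounds, it also remains open whether a different group on this ring, such as an amine or a carboxylic acid, would move the number in this assay beyond the scatter, since the single step read here with both ends measured stays within it.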